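The source may hold more compounds than are shown below. What is called first, only, known or untested is meant among the compounds shown, and "the series" means these compounds.

Of the compounds shown here, three built on one shared core have so far been measured in a functional assay on HTB-54 cells (Homo sapiens) for cytotoxicity, read by MTT assay, with a stated time of 72 h; a higher number here means a weaker inhibitor of growth, a lower number a stronger inhibitor of growth. Compound 1 `COc1ccc(CNc2nc([Se]C)nc3ccccc23)cc1` gives 33000 nM. Compound 2 `C[Se]c1nc(N)c2ccccc2n1` gives 18000 nM. Compound 3 `COc1ccc(CNc2nc([SeH])nc3ccccc23)cc1` gives 7110 nM, the lowest of the three numbers, with compound 2 nearest to it and compound 1 furthest from it, both gaps beyond the scatter. Only one pair of these compounds differs in a single place: a 4.6-fold lower number from compound 1 to compound 3 (0.67 log units; beyond the scatter), hydrogen in place of methyl on a selenium. Compound 2 differs from the other two in more than one place, so only its own value can be read from it.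

Compound 4 `[SeH]c1nc(NCc2ccccc2)c2ccccc2n1` has not yet been measured. Against compound 3 it shows (hydrogen in place of methoxy on an aromatic carbon), hydrogen in place of methoxy on an aromatic carbon. Among the measured compounds shown here, no measured step bears on this part of the molecule: the one measured step changes the group on the selenium, and that group is the same in compound 3 and compound 4. There is thus no measured reason to expect a step beyond the scatter in this assay. Compound 4 is therefore expected to give about 7000 nM, within a range from 2500 nM to 20000 nM. The expected step is a 1.0-fold lower number from compound 3 to compound 4 (0.01 log units; within the scatter), within the scatter.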

Compound 4, concentration for 50% growth inhibition: 31200 nM
Estimate against measurement, compound 4: 4.5-fold (0.65 log units) below; the whole stated range lies below it.
By their numbers in this assay, from the lowest: compound 3; then compounds 2, 4 and 1 (each within the scatter of the next).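

In this assay, the group on the aromatic carbon, para to a large group, turns out to matter: hydrogen in place of methoxy gives a 4.4-fold higher number from compound 3 to compound 4 (0.64 log units; beyond the scatter), so this part of the molecule, which the earlier step on the selenium left untouched, does affect the number. Compound 3 now has the lower number against both compounds that differ from it in one place, compound 1 with methyl on the selenium and compound 4 without the methoxy. No other measurement accompanies this result, so what lies behind the step remains unknown.

Among the compounds shown, only methoxy and hydrogen appear at this position, so it remains open whether another group there, such as a hydroxyl, a chlorine or an ethoxy, would give a number nearer that of compound 3 or that of compound 4. From the compounds shown here alone, it also remains open whether the step would have the same size and direction with methyl instead of hydrogen on the selenium.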